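Adding one methyl to compound 2: working notes

The source may hold more compounds than are shown below. What is called first, only, known or untested is meant among the compounds shown, and "the series" means these compounds.

In a functional assay on DU-145 cells (Homo sapiens) for inhibition, read by MTT assay, with a stated time of 72 h (a higher number here means a weaker inhibitor, a lower number a stronger inhibitor), compound 1 `Cc1ccc(N2CCN(C3=CC(=O)c4ccccc4C3=O)CC2)cc1` gives 8200 nM and compound 2 `O=C1C=C(N2CCN(c3ccccc3)CC2)C(=O)c2ccccc21` gives 9900 nM. Only these two numbers are at hand. They lie within the scatter of each other, so compound 2 stands level with compound 1 and neither can be ranked. The next compound is compound 3 `Cc1ccccc1N1CCN(C2=CC(=O)c3ccccc3C2=O)CC1`, and the change from compound 2 is methyl in place of hydrogen on an aromatic carbon, ortho to a large group.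

Within the data shown here, one measured step bears on this, a 1.2-fold higher number from compound 1 to compound 2 (0.08 log units; within the scatter). It is the same kind of exchange run the other way, hydrogen in place of methyl on an aromatic carbon, and it stays small. Among the measured compounds shown here, the methyl of compound 1 is not ortho to a large group, so no measured compound tests the new place, and the range below is kept wide. No step beyond the scatter is expected in this assay, and the estimated step is a 1.2-fold lower number from compound 2 to compound 3 (0.07 log units; within the scatter) as a working figure. Compound 3 is estimated at 8500 nM, with an expected range of 4000 nM to 18000 nM.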

Compound 3, half-maximal inhibitory concentration: 5700 nM
The estimate for compound 3 lay 1.5-fold (0.17 log units) above the measured number; measured number inside the range.
By their numbers in this assay, from the lowest: compounds 3, 1 and 2 (each within the scatter of the next).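

Working notes on the methyl series, continued.

In this assay, among these compounds, methyl on an aromatic carbon ortho to a large group, a place no earlier compound covered, gives a 1.7-fold lower number from compound 2 to compound 3 (0.24 log units; within the scatter), so this place adds a step of the same class as the one already seen, still inside the scatter. The exchange of 4-methylphenyl for 2-methylphenyl on the ring amine nitrogen gives a 1.4-fold lower number from compound 1 to compound 3 (0.16 log units; within the scatter), which means the two placings of the methyl cannot be told apart in this read-out, and compounds 1, 2 and 3 stand level, with none of them ranked above another. Nothing on hand explains these steps, and no measurement beyond the cell read-out bears on them.

Open, from the compounds shown here alone, is whether a group other than methyl on the same aromatic carbon, such as methoxy, chlorine, an amine or a carboxylic acid, would give a step beyond the scatter. Also open, going by these compounds, is whether a longer chain such as ethyl in that place, or any change on the shared core away from this aromatic ring, would separate compounds in this assay at all.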